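Swapping a pyridine for a thiophene on a shared core

The source may report more compounds than this note shows. Statements on the series, on what has been measured and on what is new or still open speak of the compounds shown alone.

Compound 1 `Oc1cccc(-c2cc(-c3ccncc3)nc(-c3cccc(Cl)c3)c2)c1` carries a pyridin-4-yl group, a 3-chlorophenyl group and a 3-hydroxyphenyl group around its core. In a functional assay on DU-145 cells (Homo sapiens) for cytotoxicity, read by CCK-8 assay and cell counting, with a stated time of 2 days (on this read-out lower numbers stand for stronger inhibition and higher numbers for weaker inhibition), compound 1 has no result: its entry reads "not determined" (no result reported), so it gives no number to stand on. Among the measured compounds shown here, the only measured reference is compound 2 `Oc1ccc(-c2cc(-c3ccsc3)nc(-c3ccccc3Cl)c2)cc1`, which shares the core but differs in several places at once; in this assay compound 2 gives 3890 nM. Compound 3 `Oc1cccc(-c2cc(-c3cccc(Cl)c3)nc(-c3cccs3)c2)c1` is the new compound, and it differs from compound 1 in one place: thiophen-2-yl in place of pyridin-4-yl on an aromatic carbon. For the measured compounds named here, with no measured pair showing what this exchange does on this core, no direction for the step can be read from the data, and any shift beyond the usual scatter of this assay is neither supported nor excluded. The estimate for compound 3 rests only on compound 2 and its value of 3890 nM as the single anchor on this core. Compound 3 is therefore expected to reach about 3000 nM in this assay, with a plausible range from 700 nM to 13000 nM.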

Compound 3, half-maximal inhibitory concentration: 2650 nM
Estimate against measurement, compound 3: 1.1-fold (0.05 log units) above, and the stated range covers the measured number.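

Compound 1 has no number in this assay to set beside compound 3, so no step can be read between them. The compounds shown leave open what exchanging pyridin-4-yl for thiophen-2-yl does on the shared core, in both direction and size. Nothing shown bears on the result for compound 3.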